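Toward compound 3 from compound 2: an amine enters the chain

This account rests on a few compounds, and the source may have more. Where it says the series, first, only, none or still open, it means among the compounds named here.

In an assay for binding affinity to Melanocortin receptor 4 (Homo sapiens) (a lower number here means a stronger inhibitor, a higher number a weaker inhibitor), two compounds have been measured. Compound 1, `CCN(CC)CCCC(C)/N=C(/N)NC(=O)c1cccc(F)c1OCc1cc(Br)ccc1OC`, gives 900 nM. Compound 2, `COc1ccc(Br)cc1CCc1c(F)cccc1C(=O)/N=C(\N)NCCC1CCCCC1`, gives 2600 nM, the highest of the two numbers; its nearest neighbour, compound 1, lies beyond the scatter with its lower number. Compound 3, `COc1ccc(Br)cc1CCc1c(F)cccc1C(=O)/N=C(\N)NCCCCN(C)Cc1ccccc1`, has not yet been measured in this assay. It differs from compound 2 in one place: 2-(benzyl(methyl)amino)ethyl in place of cyclohexyl on a saturated chain carbon, two bonds along the chain from an amine nitrogen. The chain of compound 3 thus again carries an amine nitrogen, as the chain of compound 1 does. Among the compounds with values here, since no step between measured compounds is available, the expectation rests on the two values alone. The step from compound 2 to compound 3 is estimated at a 3.3-fold lower number from compound 2 to compound 3 (0.51 log units; beyond the scatter), downward and modestly beyond the scatter, because compound 1 gives 900 nM in this assay. For compound 3 the estimate is 800 nM, within a range from 200 nM to 3000 nM.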

Compound 3, inhibition constant: 5.1 nM
The estimate for compound 3 lay 160-fold (2.20 log units) above the measured number, and the stated range ends above it.
By their numbers in this assay, from the lowest: compound 3; then compound 1; then compound 2.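

In this assay the group at this place on the chain turns out to matter far more than the two earlier values could show: the change from cyclohexyl to 2-(benzyl(methyl)amino)ethyl brings a 510-fold lower number from compound 2 to compound 3 (2.71 log units; beyond the scatter) in a single step. That step brings in an amine nitrogen and an aromatic ring of carbon only together, with 11 heavy atoms in place of 6, so it does not assign the gain to any one of these. Nothing measured here accounts for the size of the step.

The compounds shown leave open whether the amine nitrogen alone carries the gain, which a dimethylamino group at the chain end would test, or whether the benzyl group is also needed. They also leave open how a shorter or longer chain carrying the same amine would compare.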